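Replacing phenyl with dichlorophenyl on the amide side chain

The source may report more compounds than this note shows. Statements on the series, on what has been measured and on what is new or still open speak of the compounds shown alone.

Of the compounds shown here, three sharing one core have been tested in an ADME assay on J774 cells (Mus musculus) for cytotoxicity, read by MTT assay, with a stated time of 48 h; a lower number here means a stronger inhibitor, a higher number a weaker inhibitor. Compound 1 `NCCCCNc1cc(/C=C/c2ccccc2)nc2ccccc12` gives 6600 nM. Compound 2 `O=C(CN1CCCC1)NCCCCNc1cc(/C=C/c2ccccc2)nc2ccccc12` gives 7100 nM, and compound 3 `O=C(CNc1ccccc1)NCCCCNc1cc(/C=C/c2ccccc2)nc2ccccc12` gives 3300 nM. Compound 3 has the lowest of the three numbers, though its gap to compound 1 is within the scatter; only a 2.2-fold lower number from compound 2 to compound 3 (0.33 log units; beyond the scatter) counts as a real, if modest, step.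

Compound 4 `O=C(CNc1ccc(Cl)cc1Cl)NCCCCNc1cc(/C=C/c2ccccc2)nc2ccccc12` differs from compound 3 in one place: 2,4-dichlorophenyl in place of phenyl on an amine nitrogen. Going by the values given here, of the measured steps, only the one from compound 2 to compound 3 touches this part of the molecule, and it was modest. Among the compounds with values here, no measured step tells what adding two chlorines to that ring does. The expectation is therefore a number close to that of compound 3, without a step beyond the scatter.

Compound 4 is expected to give about 2800 nM, with a range from 1100 nM to 7500 nM. This estimate amounts to an expected step of a 1.2-fold lower number from compound 3 to compound 4 (0.07 log units; within the scatter).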

Compound 4, half-maximal inhibitory concentration: 7300 nM
Compound 4: middle estimate off by 2.6-fold (0.42 log units), on the low side; low and high end bracket the measured number.
By their numbers in this assay, from the lowest: compounds 3, 1, 2 and 4 (each within the scatter of the next, the first and the last beyond it).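

In this assay, going by these compounds alone, the substituents on the phenyl ring prove able to shift the number: 2,4-dichlorophenyl in place of phenyl gives a 2.2-fold higher number from compound 3 to compound 4 (0.34 log units; beyond the scatter) as a modest step, the first measured change to this ring. The other two comparisons give a 1.0-fold higher number from compound 2 to compound 4 (0.01 log units; within the scatter) and a 1.1-fold higher number from compound 1 to compound 4 (0.04 log units; within the scatter) and so stay within the scatter, which means that the dichlorinated side chain cannot be told apart from the pyrrolidin-1-yl side chain or from hydrogen on the amine nitrogen. No measurement available here explains the step.

The compounds shown leave open whether both chlorines are needed for this step, since 2-chlorophenyl and 4-chlorophenyl are not among them. Also open, on these data alone, is whether a group other than chlorine on this ring, such as methoxy or methyl, would move the number the same way.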